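A few compounds are considered here, and "the series" means these few. Any claim that something is new, unique, unknown or untested is made for them only; others in the source may bear on it.

Series notes. Compound 1 `O=[N+]([O-])c1ccc(S(=O)(=O)N(CCCN2CCN(c3ccccc3)CC2)CC2CCCCC2)cc1` carries a nitro group on the aromatic ring attached to the sulfonyl sulfur; in an assay on CHO cells for displacement of a labelled ligand from 5-hydroxytryptamine receptor 7 (Homo sapiens) (a lower number here means a stronger inhibitor, a higher number a weaker inhibitor), compound 1 gives 87 nM. Compound 2 `COc1ccc(S(=O)(=O)N(CCCN2CCN(c3ccccc3)CC2)CC2CCCCC2)cc1` differs from it only in that ring substituent, and in this assay compound 2 gives 567 nM. For the measured compounds named here, the single measured step, a 6.5-fold higher number from compound 1 to compound 2 (0.81 log units; beyond the scatter), shows that the group sitting on the sulfonyl sulfur shifts the number clearly. Going by the values given here, compound 2 therefore stands with the highest of the two numbers so far, compound 1 being its only neighbour.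

Compound 3 `O=S(=O)(c1ccc2ccccc2c1)N(CCCN1CCN(c2ccccc2)CC1)CC1CCCCC1` is the next member: naphthalen-2-yl in place of 4-methoxyphenyl on a sulfonyl sulfur. Among the compounds with values here, no measured pair exchanges the whole aryl group on the sulfonyl sulfur; the only step that bears on this site is a 6.5-fold higher number from compound 1 to compound 2 (0.81 log units; beyond the scatter), which concerns a substituent on that ring rather than its replacement, so it sets the scale of what a change there can do without fixing the direction here. The expectation for compound 3 in this assay is a modest move toward a lower number, a 2.8-fold lower number from compound 2 to compound 3 (0.45 log units; beyond the scatter), with wide uncertainty. Compound 3 is estimated at 200 nM, within 50 nM to 800 nM.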

Compound 3, half-maximal inhibitory concentration: 1240 nM
The estimate for compound 3 lay 6.2-fold (0.79 log units) below the measured number; measured number above the stated range.
By their numbers in this assay, from the lowest: compound 1; then compound 2; then compound 3.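

Exchanging the whole aryl group on the sulfonyl sulfur, rather than a substituent on that ring, moves the number upward in this assay: naphthalen-2-yl in place of 4-methoxyphenyl gives a 2.2-fold higher number from compound 2 to compound 3 (0.34 log units; beyond the scatter), and naphthalen-2-yl in place of 4-nitrophenyl gives a 14-fold higher number from compound 1 to compound 3 (1.15 log units; beyond the scatter). The second six-membered aromatic ring therefore brings no gain at this site in either comparison, and among the three aryl groups shown, naphthalen-2-yl carries the highest number and 4-nitrophenyl the lowest. Nothing available accounts for this order.

On these data alone, whether the order extends to other groups on the sulfonyl sulfur stays open, and a 4-aminophenyl, a 4-carboxyphenyl or a plain methyl in place of the aryl group would show how far it holds and whether an aromatic ring is needed there at all. As far as these compounds go, the rest of the shared core is constant across all three compounds, so how a longer chain or an amide in that part would alter these steps also remains open.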